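Compound 3: A Chlorinated Swap on an Inactive Series

The compounds below may be only part of what the source reports. "The series", "measured", "known", "first", "only" and "open" are said of these compounds alone.

Measured compounds:
- Compound 1 `COc1ccc(-c2noc(-c3ccncc3)n2)cc1OC1CCCC1`: > 1000000 nM (a limit)
- Compound 2 `COc1ccc(-c2noc(Cc3c[nH]c4ccccc34)n2)cc1OC1CCCC1`: > 1000000 nM (a limit)

In a functional assay on MCF7 cells (Homo sapiens) for antiproliferative activity, read by MTT assay, with a stated time of 24 h (on this read-out lower numbers stand for stronger inhibition and higher numbers for weaker inhibition), compound 1 stands at the limit of > 1000000 nM in this assay, at which 2 of the 2 values shown sit. No number is therefore available for either measured compound. Compound 3 `COc1ccc(-c2noc(-c3ccc(Cl)cc3)n2)cc1OC1CCCC1` has not yet been measured. It differs from compound 1 by 4-chlorophenyl in place of pyridin-4-yl on an aromatic carbon, with 4-chlorophenyl in place of pyridin-4-yl on an aromatic carbon. No measured step sizes this change. A modest move toward stronger inhibition in this assay is nonetheless expected, estimated as an at least 1.6-fold lower number from compound 1 to compound 3 (0.22 log units; that floor lies within the scatter). Another limit would be no surprise. For compound 3 the estimated value is 600000 nM, with an expected range from 60000 nM to 2000000 nM.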

Compound 3, half-maximal inhibitory concentration: 174000 nM
The estimate for compound 3 lay 3.4-fold (0.54 log units) above the measured number; the range from low to high includes it.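

With 4-chlorophenyl in place of pyridin-4-yl on this aromatic carbon, this assay shows an at least 5.7-fold lower number from compound 1 to compound 3 (0.75 log units; beyond the scatter). The position therefore responds to what it carries, which two compounds sitting at the same limit could not show. Compound 3 is the only one of the three with a number rather than a limit: the limit of > 1000000 nM in this assay, at which 2 of the 3 values shown sit.

The change swaps the chlorine in and the ring nitrogen out together, and the compounds shown do not separate the two. From the compounds shown here alone, how a plain phenyl, or a phenyl bearing a methoxy group or an amine, would read at this position remains open.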